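Propyl to tert-butyl on two related cores

A few compounds are considered here, and "the series" means these few. Any claim that something is new, unique, unknown or untested is made for them only; others in the source may bear on it.

Compound 1 `C=CCn1ncc2c(C)nc(CCC)n2c1=O` bears a propyl group on its core, and in a functional assay for inhibition, with Homo sapiens as the target (a lower number here means a stronger inhibitor, a higher number a weaker inhibitor), compound 1 gives 40000 nM. Compound 2 `C=CCn1ncc2c(C)nc(C(C)(C)C)n2c1=O` differs from compound 1 by tert-butyl in place of propyl on an aromatic carbon. In this assay compound 2 returns only a limit of the assay, > 48000 nM. The step of an at least 1.2-fold higher number from compound 1 to compound 2 (0.07 log units; that floor lies within the scatter) is thus a floor rather than a measured difference, and it rests on (the limit of > 48000 nM in this assay, at which 2 of the 3 values shown sit).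

Compound 3 `CCCc1ncc2cnnc(O)n12` is built on another core; the difference between the two cores is not broken down here. In this assay compound 3 likewise returns only a limit of the assay, > 48000 nM. Compound 4 `CC(C)(C)c1ncc2cnnc(O)n12` has not yet been measured and differs from compound 3 by tert-butyl in place of propyl on an aromatic carbon. The surroundings of the change are not identical to those in compound 1, where the change sits two ring bonds from the ring atom that bears a methyl group; compound 3 has no such group at that position, so the change in compound 4 is the same kind of change, not the same one.

Given that compound 3 is already at the limit, and that the corresponding step in the first pair is a floor within the scatter, compound 4 is expected to move by about a step that the limit leaves unreadable from compound 3 to compound 4. Compound 4 is therefore estimated at 70000 nM in this assay, most likely reported again as a limit, with an expected range from 48000 nM to 250000 nM.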

Compound 4, half-maximal inhibitory concentration: > 48000 nM
Compound 4 was reported as a limit; the forecaster's own chance of this, stated with the estimate: 90%; the middle value is on the limit's open side.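

No step can be read between compound 3 and compound 4, tert-butyl in place of propyl, because both stand at a limit in this assay: the limit of > 48000 nM in this assay, at which 3 of the 4 values shown sit.

The compounds shown leave open whether this change alters inhibition at all on the core of compound 3, and how large the same kind of change is on the core of compound 1.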